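Compound 4: 4-(methylsulfanyl)phenyl replaces 3-fluorophenyl

The source may report more compounds than this note shows. Statements on the series, on what has been measured and on what is new or still open speak of the compounds shown alone.

In a functional assay on HL-60 cells (Homo sapiens) for antiproliferative activity, read by MTT assay, with a stated time of 72 h (a lower number here means a stronger inhibitor, a higher number a weaker inhibitor), compound 3 (`COc1cc(-n2ncnc2-c2cccc(F)c2)cc(OC)c1OC`) gives > 10000 nM, which is a limit and not a number. Compound 2 (`COc1cc(-n2ncnc2-c2cccc(Cl)c2)cc(OC)c1OC`) gives > 10000 nM, which is also a limit. The set therefore shows (the limit of > 10000 nM in this assay, at which 2 of the 3 values shown sit). Compound 1 (`COc1cc(-n2ncnc2-c2ccc(OC(C)C)cc2)cc(OC)c1OC`) gives a true number in this assay, 700 nM, so the shared core can return a readable value.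

The change to compound 4 (`COc1cc(-n2ncnc2-c2ccc(SC)cc2)cc(OC)c1OC`) is 4-(methylsulfanyl)phenyl in place of 3-fluorophenyl on an aromatic carbon. In it, 4-(methylsulfanyl)phenyl stands in place of 3-fluorophenyl on an aromatic carbon of the five-membered aromatic ring with 3 nitrogen.

Among the measured compounds shown here, only one measured step exists, a step that the two limits leave unreadable from compound 2 to compound 3, and it gives no size to carry over. The expectation therefore rests on the value of compound 1 at 700 nM, which shows that a number is possible with a different aryl group on the shared core. That is thin support, and a result at the limit remains possible for compound 4.

The expected step is an at least 16-fold lower number from compound 3 to compound 4 (1.22 log units; beyond the scatter), toward stronger inhibition, with its size only estimated. For compound 4 the estimate is 600 nM, with an expected range of 60 nM to 6000 nM.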

Compound 4, half-maximal inhibitory concentration: 500 nM
Estimate against measurement, compound 4: 1.2-fold (0.08 log units) above; measured number inside the range.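

In this assay the 4-(methylsulfanyl)phenyl group replacing 3-fluorophenyl gives an at least 20-fold lower number from compound 3 to compound 4 (1.30 log units; beyond the scatter), and the same group replacing 3-chlorophenyl gives an at least 20-fold lower number from compound 2 to compound 4 (1.30 log units; beyond the scatter). With methylsulfanyl in place of isopropoxy there is a 1.4-fold lower number from compound 1 to compound 4 (0.15 log units; within the scatter), so compound 1 and compound 4 cannot be told apart, and a second aryl group on the shared core now returns a readable number. Both large steps start from a limit and not from a number, so their full size stays unknown: the limit of > 10000 nM in this assay, at which 2 of the 4 values shown sit.

Among the compounds shown, the two groups with a readable number differ from the two at the limit both in the substituent and in its place on the phenyl ring, so the two effects cannot be separated. Also open, going by these compounds, is whether an amine, a carboxylic acid or a longer chain such as butoxy on that phenyl ring would keep a readable number, or whether any such group would give a step beyond the scatter from compound 4.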